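Adding a Diethylcarbamoyl Group to Compound 3

The source may hold more compounds than are shown below. What is called first, only, known or untested is meant among the compounds shown, and "the series" means these compounds.

Three measured compounds share a core. Compound 1 `COc1ccc2cc(-c3ccccc3)c(O)nc2c1` was tested in a functional assay on T-24 cells (Homo sapiens) for cytotoxicity, read by colorimetric assay and MTT assay (on this read-out higher numbers stand for weaker inhibition and lower numbers for stronger inhibition), where compound 1 gives 10000 nM. Compound 2 `COc1ccc(-c2cc3cccc(OC)c3nc2O)cc1` in this assay gives 10000 nM. Compound 3 `COc1ccc(-c2cc3c(OC)cc(OC)cc3n(C)c2=O)cc1`, which carries a methyl on its aromatic nitrogen, gives 10000 nM in this assay. On these numbers compound 3 stands level with compounds 1 and 2 at the digits shown; the gap to either lies within the scatter, so no ordering among the three can be read from this set.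

Compound 4 `CCN(CC)C(=O)Cn1c(=O)c(-c2ccc(OC)cc2)cc2c(OC)cc(OC)cc21` has not yet been measured. It differs from compound 3 in one place: diethylcarbamoyl in place of hydrogen on a saturated chain carbon bound to an aromatic nitrogen. Viewed one bond further out, the same change reads as methyl to (diethylcarbamoyl)methyl.

For the measured compounds named here, no step between measured compounds is available here, so nothing shows how additions on the saturated chain carbon bound to the aromatic nitrogen play out in this assay. Going by the values given here, with compound 3 at 10000 nM and nothing among the measured compounds to suggest otherwise, the expected step of no change at the digits printed from compound 3 to compound 4 (within the scatter) is none beyond the scatter. Compound 4 is therefore estimated at 10000 nM, within a range from 3000 nM to 30000 nM.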

Compound 4, half-maximal inhibitory concentration: 10000 nM
Beside the measured number, compound 4's estimate shows no gap at the digits printed; the range from low to high includes it.
By their numbers in this assay, from the lowest: compounds 1, 2, 3 and 4 (each within the scatter of the next).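

In this assay, for the compounds shown here, putting diethylcarbamoyl in place of hydrogen on a saturated chain carbon bound to an aromatic nitrogen gives no change at the digits printed from compound 3 to compound 4 (within the scatter) as the only step here that isolates one change. The earlier compounds shown here could not show this, as no two of them differ in one place, whereas this step shows that a group of 7 heavy atoms, one of them a carbonyl oxygen and one an amide nitrogen, can sit at this place with no shift in the read-out beyond the scatter. No measurement in hand offers an explanation for this flat result.

From the compounds shown here alone, whether any other group at this place would shift the read-out remains open, for instance a primary amine, a carboxylic acid or a longer alkyl chain, each to be set against compound 3 at 10000 nM in this assay as the reference. Also open, going by these compounds, is whether the ethyl groups of the amide matter at all, a question that a smaller dimethylcarbamoyl group or a ring-closed morpholine amide at the same place could address.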